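Changing the ring on the sulfur of compound 3

A few compounds are considered here, and "the series" means these few. Any claim that something is new, unique, unknown or untested is made for them only; others in the source may bear on it.

Compound 3 `CC1(C)O[C@H]2[C@H](OCc3noc(-c4ccc([N+](=O)[O-])cc4)n3)O[C@H](CSc3nnc(N)s3)[C@H]2O1` stands at the edge of what a functional assay on WiDr cells (Homo sapiens) for antiproliferative activity, read by sulforhodamine B assay, with a stated time of 48 h (a lower number here means a stronger inhibitor of growth, a higher number a weaker inhibitor of growth), can report: in this assay compound 3 gives > 100000 nM, which is a limit and not a number. Compound 1 `CC1(C)O[C@H]2[C@H](OCc3noc(-c4ccc([N+](=O)[O-])cc4)n3)O[C@H](CO)[C@H]2O1` gives > 100000 nM in this assay, also a limit. The step that the two limits leave unreadable from compound 1 to compound 3 therefore cannot be read, as the limit of > 100000 nM in this assay, at which 2 of the 3 values shown sit, shows. Within the data shown here, compound 2 `COc1cc(-c2nc(CO[C@@H]3O[C@H](CSc4ncn[nH]4)[C@H]4OC5(CCCC5)O[C@@H]34)no2)cc(OC)c1OC`, which carries a (1H-1,2,4-triazol-5-yl)sulfanyl group on a different core, gives 42000 nM in this assay; no single-point step connects it to the others. Compound 4 `CC1(C)O[C@H]2[C@H](OCc3noc(-c4ccc([N+](=O)[O-])cc4)n3)O[C@H](CSc3ncn[nH]3)[C@H]2O1` differs from compound 3 by 1H-1,2,4-triazol-5-yl in place of 5-amino-1,3,4-thiadiazol-2-yl on a sulfur. No measured step covers this change, so the steps shown give no expected size or direction in this assay. Compound 4 is expected to give 100000 nM, between 40000 nM and 300000 nM. That estimate means a step of a number no higher from compound 3 to compound 4 (the limit leaves the size open) that is expected to stay within the scatter.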

Compound 4, concentration for 50% growth inhibition: > 100000 nM
Compound 4: no number, only a limit; the forecaster's own chance of this, stated with the estimate: 60%; the middle value lies on the limit itself.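

Among these compounds, no step among compound 1, compound 3 and compound 4 can be read in this assay, since each gives only a limit: the limit of > 100000 nM in this assay, at which 3 of the 4 values shown sit.

The compounds shown leave open whether swapping 5-amino-1,3,4-thiadiazol-2-yl for 1H-1,2,4-triazol-5-yl on a sulfur changes growth inhibition at all on this core.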